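The source may hold more compounds than are shown below. What is called first, only, known or untested is meant among the compounds shown, and "the series" means these compounds.

Compound 1 `CC(C)C[C@H](N)c1cc(C(F)(F)F)ccc1N1CCN(C(=O)C(C)Cc2ccc(Cl)cc2O)CC1` and compound 2 `CC(C)C[C@H](N)c1cc(C(F)(F)F)ccc1N1CCN(C(=O)CCC(=O)c2ccc(Cl)cc2)CC1` share one core and differ only in the group on the carbonyl carbon. In an assay on HEK293 cells for displacement of a labelled ligand from Melanocortin receptor 4 (Homo sapiens) (on this read-out lower numbers stand for stronger inhibition and higher numbers for weaker inhibition), compound 1 gives 36 nM. In this assay compound 2 gives 820 nM, the higher of the two numbers, and its nearest neighbour is compound 1, as the step of a 23-fold higher number from compound 1 to compound 2 (1.36 log units; beyond the scatter) shows. Compound 3 `Cc1cc(Cl)ccc1CC(C)C(=O)N1CCN(c2ccc(C(F)(F)F)cc2[C@@H](N)CC(C)C)CC1` has not yet been measured; it differs from compound 2 in one place: 1-(4-chloro-2-methylbenzyl)ethyl in place of 2-((4-chlorophenyl)carbonyl)ethyl on a carbonyl carbon. The entering group is the same as the group in compound 1 except that a methyl stands where compound 1 carries a hydroxyl. Among the measured compounds shown here, the only measured step that bears on this change is a 23-fold higher number from compound 1 to compound 2 (1.36 log units; beyond the scatter), which compound 3 largely reverses; the hydroxyl-to-methyl difference has no measured counterpart. Compound 3 is therefore expected to move back towards compound 1, with a step of a 9.1-fold lower number from compound 2 to compound 3 (0.96 log units; beyond the scatter) in this assay. Compound 3 is estimated at 90 nM, in the range 25 nM to 350 nM.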

Compound 3, inhibition constant: 38 nM
For compound 3 the middle estimate is 2.4-fold (0.37 log units) above the measured one; the measured number falls inside the stated range.
By their numbers in this assay, from the lowest: compounds 1 and 3 (each within the scatter of the next); then compound 2.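

Replacing 2-((4-chlorophenyl)carbonyl)ethyl with 1-(4-chloro-2-methylbenzyl)ethyl on the carbonyl carbon gives a 22-fold lower number from compound 2 to compound 3 (1.33 log units; beyond the scatter) in this assay, so a large step at this position is seen with a second entering group. The hydroxyl of compound 1 is not required for this level of inhibition: methyl in place of hydroxy on the aromatic carbon gives a 1.1-fold higher number from compound 1 to compound 3 (0.02 log units; within the scatter) and leaves the two compounds indistinguishable, even though the group in compound 3 has no hydrogen-bond donors. Nothing measured here explains this result.

On these data alone, whether a methoxy group, an amine or plain hydrogen on that aromatic carbon would read the same remains open. Also open is which feature of the entering group accounts for the large step, as its branched chain and the aromatic methyl change together.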